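Closing the Chain Amine into a Ring

This account rests on a few compounds, and the source may have more. Where it says the series, first, only, none or still open, it means among the compounds named here.

Three compounds have so far been measured in a functional assay on BCG823 cells (Homo sapiens) for antiproliferative activity, read by MTT assay, with a stated time of 48 h; a lower number here means a stronger inhibitor, a higher number a weaker inhibitor:

Compound 1 `CN1CCN(CCCCOc2c(O)cc3oc(-c4ccccc4)cc(=O)c3c2O)CC1` gives 82900 nM
Compound 2 `CCN(CC)CCCCOc1c(OCc2ccccc2)cc2oc(-c3ccccc3)cc(=O)c2c1O` gives 4200 nM
Compound 3 `COc1cc2oc(-c3ccccc3)cc(=O)c2c(O)c1OCCCN1CCN(C)CC1` gives 31300 nM

Compound 2 stands lowest of the three. Compound 3 gives the nearest higher number and compound 1 the highest, and both of those gaps lie beyond the usual scatter, so compound 2 is the strongest inhibitor among the measured set. No two of these compounds differ in only one place, so no single step between measured compounds can be read off.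

Compound 4 `O=c1cc(-c2ccccc2)oc2cc(OCc3ccccc3)c(OCCCCN3CCCCC3)c(O)c12` has not yet been measured in this assay. It differs from compound 2 in one place: piperidin-1-yl in place of diethylamino on a saturated chain carbon, four bonds along the chain from an oxygen on an aromatic ring. The open amine at the end of the chain thus becomes a six-membered non-aromatic ring with one hetero atom, while the rest of the molecule stays as in compound 2. For the measured compounds named here, with no comparable step among the measured compounds, the change is expected to move the number little, in no clear direction, and most likely within the scatter.

Compound 4 is therefore estimated at about 4000 nM, within a range from 1500 nM to 12000 nM. The expected step is a 1.1-fold lower number from compound 2 to compound 4 (0.02 log units; within the scatter), which is expected to stay within the scatter.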

Compound 4, half-maximal inhibitory concentration: 3000 nM
Compound 4: the middle estimate sits 1.3-fold (0.12 log units) above what was measured; the range from low to high includes it.
By their numbers in this assay, from the lowest: compounds 4 and 2 (each within the scatter of the next); then compound 3; then compound 1.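

In this assay, replacing diethylamino with piperidin-1-yl at this place on the chain gives a 1.4-fold lower number from compound 2 to compound 4 (0.15 log units; within the scatter), so the two compounds cannot be told apart. For the compounds shown here, this is the first single-place step in the set, and it shows that joining the two open ethyl arms of the end amine into a ring leaves the number within the scatter, with the rest of the molecule held fixed. No supporting measurement is available to explain this result.

This is a single step at a single place, so it cannot say whether other end groups, such as morpholin-4-yl, pyrrolidin-1-yl or dimethylamino, would also leave the number within the scatter. Also open, as far as these compounds go, is whether piperidin-1-yl would behave the same way on a longer chain or a shorter one.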